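The source may hold more compounds than are shown below. What is called first, only, known or untested is meant among the compounds shown, and "the series" means these compounds.

Two compounds have been measured in an assay on isolated protein for inhibition of Amine oxidase [flavin-containing] B (Homo sapiens), read by fluorescence; on this read-out higher numbers stand for weaker inhibition and lower numbers for stronger inhibition:

Compound 1, `Cn1c(=O)c2c(nc(SCCOc3ccccc3)n2C)n(C)c1=O`, gives 332 nM.
Compound 2, `Cn1c(=O)c2c(nc(SCc3ccc(Br)cc3)n2C)n(C)c1=O`, gives 167 nM.

Compound 2 has the lower of the two numbers, yet the step of a 2.0-fold lower number from compound 1 to compound 2 (0.30 log units; within the scatter) is within the scatter, so the two compounds cannot be told apart on these data. Both share the same core and differ only in the group on a saturated chain carbon bound to a sulfur.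

Compound 3, `CC(C)CCSc1nc2c(c(=O)n(C)c(=O)n2C)n1C`, has not yet been measured. It differs from compound 2 in this way: isobutyl in place of 4-bromophenyl on a saturated chain carbon bound to a sulfur. Within the data shown here, the only measured step that bears on this change is the one from compound 1 to compound 2, which also altered the group at this place and was within the scatter. With a single step of that size as a guide, no change beyond the scatter is expected in this assay, although the loss of the ring leaves room for a somewhat higher number. Compound 3 is therefore estimated at 300 nM, within a range from 100 nM to 1000 nM. This estimate corresponds to an expected step of a 1.8-fold higher number from compound 2 to compound 3 (0.25 log units; within the scatter).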

Compound 3, half-maximal inhibitory concentration: 2620 nM
The estimate for compound 3 lay 8.7-fold (0.94 log units) below the measured number, outside the stated range (above it).
By their numbers in this assay, from the lowest: compounds 2 and 1 (each within the scatter of the next); then compound 3.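

In this assay, among these compounds, the group on a saturated chain carbon bound to a sulfur now clearly matters: isobutyl in place of 4-bromophenyl gives a 16-fold higher number from compound 2 to compound 3 (1.20 log units; beyond the scatter), whereas the only earlier change at this place stayed within the scatter. A second comparison points the same way, since isopropyl in place of phenoxy on a saturated chain carbon, two bonds along the chain from a sulfur, gives a 7.9-fold higher number from compound 1 to compound 3 (0.90 log units; beyond the scatter), so among these three compounds the two with an aromatic ring in this group have the lower numbers and compound 3, with no ring, has the highest. No measurement available here explains why the number rises when the ring leaves.

These compounds cannot show whether the ring itself or some other difference between the groups accounts for the rise, nor what the bromine contributes to compound 2. A plain phenyl in place of 4-bromophenyl would isolate the bromine, while a cyclohexyl would test a ring of carbon that is not aromatic, and a chain ending in an amine remains an untested kind of group at this place.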